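Iodo for Isopropyl on the Aromatic Ring: What to Expect

A few compounds are considered here, and "the series" means these few. Any claim that something is new, unique, unknown or untested is made for them only; others in the source may bear on it.

Two compounds carry numbers in a functional assay on HT-1080 cells (Homo sapiens) for antiproliferative activity, read by sulforhodamine B assay, with a stated time of 48 h; a higher number here means a weaker inhibitor, a lower number a stronger inhibitor. Compound 1 `CCCCCC(=O)Nc1ccc(S(=O)(=O)Oc2ccccc2I)cc1` gives 9600 nM in this assay. Compound 2 `CC(C)c1ccccc1OS(=O)(=O)c1ccc(NC(=O)CCl)cc1` gives 1000 nM, the lower of the two numbers, with compound 1 standing well beyond the scatter above it. These two compounds differ in more than one place, so what the gap between them shows cannot be tied to any single change.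

Compound 3 `O=C(CCl)Nc1ccc(S(=O)(=O)Oc2ccccc2I)cc1` is reached from compound 2 by one change: iodo in place of isopropyl on an aromatic carbon. Going by the values given here, no measured pair isolates this exchange, so its effect is not known from the data. Compound 1 carries the same iodo group at the same place, yet its amide differs from that of compound 2. In this assay compound 1 gives 9600 nM, and since compound 1 differs from compound 2 in more than the iodo group, that number does not isolate the exchange. On that basis the expected step is a 1.5-fold higher number from compound 2 to compound 3 (0.18 log units; within the scatter), a shift not clearly beyond the scatter, with some allowance for a weaker result. Compound 3 is therefore estimated at 1500 nM in this assay, within a range from 400 nM to 6000 nM.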

Compound 3, half-maximal inhibitory concentration: 600 nM
The estimate for compound 3 lay 2.5-fold (0.40 log units) above the measured number, and the stated range covers the measured number.
By their numbers in this assay, from the lowest: compounds 3 and 2 (each within the scatter of the next); then compound 1.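

In this assay, iodo in place of isopropyl on an aromatic carbon, ortho to a large group, gives a 1.7-fold lower number from compound 2 to compound 3 (0.22 log units; within the scatter) and so leaves compound 2 and compound 3 within the scatter of each other: at this position, with the chloroacetamide side held fixed, the exchange of a three-carbon branched group for a single iodine atom shows no clear shift in the number. With the iodo group held fixed instead, chloro in place of butyl on a saturated chain carbon bound to a carbonyl carbon gives a 16-fold lower number from compound 1 to compound 3 (1.20 log units; beyond the scatter) and this large step, beyond the scatter, places the clear difference among these single changes at the chain carbon and not on the aromatic ring. Nothing at hand offers a reason for either step.

Going by these compounds, it remains open whether bromo, methoxy, an amine or a carboxylic acid at that aromatic carbon would stand with iodo and isopropyl or apart from them. On these data alone, it is also open whether the large step at the chain carbon follows from chloro itself or from the length of the chain, which a bromo or hydroxyl group at that carbon, or a propyl chain there, could help to separate.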